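Methylsulfanyl step across two compound pairs

A few compounds are considered here, and "the series" means these few. Any claim that something is new, unique, unknown or untested is made for them only; others in the source may bear on it.

Measured compounds:
compound 1, `Cc1nsc2c1ncn2[C@H]1C[C@H](O)[C@@H](CO)O1`, > 100000 nM
compound 2, `CSc1nc2c(C)nsc2n1[C@H]1C[C@H](O)[C@@H](CO)O1`, > 100000 nM
compound 3, `Cc1nsc2c1ncn2[C@@H]1O[C@H](CO)[C@@H](O)[C@H]1O`, 90000 nM

In a functional assay on KB cells (Homo sapiens) for antiproliferative activity (a higher number here means a weaker inhibitor, a lower number a stronger inhibitor), compound 1 gives > 100000 nM, which is a limit of the assay and not a number. Compound 2 in this assay also gives > 100000 nM, again a limit. For the measured compounds named here, compound 3 is the only compound with a number: in this assay compound 3 gives 90000 nM.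

The change from compound 1 to compound 2 is methylsulfanyl in place of hydrogen on an aromatic carbon. Its step, a step that the two limits leave unreadable from compound 1 to compound 2, cannot be read because of the limit of > 100000 nM in this assay, at which 2 of the 3 values shown sit.

The two cores differ by hydroxy in place of hydrogen on a saturated ring carbon; the step of an at least 1.1-fold lower number from compound 1 to compound 3 (0.04 log units; that floor lies within the scatter) has a floor within the scatter, so no direction is claimed.

Compound 4, `CSc1nc2c(C)nsc2n1[C@@H]1O[C@H](CO)[C@@H](O)[C@H]1O`, is not yet measured. It differs from compound 3 by methylsulfanyl in place of hydrogen on an aromatic carbon, the same kind of change as that from compound 1 to compound 2; around the place, the neighbouring ring atom bears a group of 9 heavy atoms here, against 8 heavy atoms in compound 1. The earlier step is unreadable, so the expected step for compound 4 is set to a 1.1-fold higher number from compound 3 to compound 4 (0.05 log units; within the scatter), essentially flat from compound 3. For compound 4 the estimate in this assay is 100000 nM, with compound 3 sitting close to the limit, so a limit-only result is expected to be likely.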

Compound 4, half-maximal inhibitory concentration: > 100000 nM
Compound 4: only a limit was reported; the forecaster's own chance of this, stated with the estimate: 60%; the middle value sits exactly at the limit.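

In this assay compound 4 gives > 100000 nM, which is a limit of the assay and not a number. Carried to the core bearing the added hydroxy, methylsulfanyl in place of hydrogen on an aromatic carbon gives an at least 1.1-fold higher number from compound 3 to compound 4 (0.04 log units; that floor lies within the scatter), so this core shows no direction for the change and no measured size for it, only a floor that does not rise beyond the usual variation between repeats. The same change on the core of compound 1 and the hydroxy change between the two methylsulfanyl compounds cannot be read, so the series offers no two step sizes to compare, and carrying the change from one core to the other is neither supported nor contradicted, the reason being where the values sit: the limit of > 100000 nM in this assay, at which 3 of the 4 values shown sit.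

Still open, going by these compounds, is whether another group at this aromatic carbon, between two ring nitrogen atoms, such as an amine, a carboxylic acid or a longer chain on the sulfur, would give a number in place of a limit. For the compounds shown here, also open is how methylsulfanyl behaves on a core whose starting value lies well clear of the limit, since the only number here sits close to it.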